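From Propyl to 2-Hydroxyethyl: Expecting Compound 4

The compounds below may be only part of what the source reports. "The series", "measured", "known", "first", "only" and "open" are said of these compounds alone.

Of the compounds shown here, three have so far been tested in a functional assay on the whole organism with Mus musculus as the target, in the writhing test; on this read-out higher numbers stand for an effect only at larger amounts of compound and lower numbers for an effect already at smaller amounts. Compound 1 `CCCn1nc2oc(=O)cc(C)c2c1C` gives 72.6 mg/kg in this assay, the higher of the two plain numbers obtained. Its nearest neighbour is compound 3 `Cc1cc(O)oc2nncc1-2`, which gives 40.6 mg/kg, a gap that lies within the scatter of repeated measurements, so neither compound can be placed ahead of the other. Compound 2 `Cc1cc(=O)oc2c1c(CC(=O)O)nn2C` reached only > 100 mg/kg, which is a limit of the assay rather than a number. One of the three results thus sits at the limit of > 100 mg/kg in this assay, at which 1 of the 3 values shown sits.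

Compound 4 `Cc1cc(=O)oc2nn(CCO)c(C)c12` has not yet been measured. It differs from compound 1 in one place: hydroxy in place of methyl on a saturated chain carbon, two bonds along the chain from an aromatic nitrogen. Among the measured compounds shown here, no pair of measured compounds shows this kind of step, so its size is unknown from the data at hand, and the cautious expectation is a step no larger than the scatter, in either direction. Compound 4 is therefore estimated to give 60 mg/kg, expected to fall between 25 mg/kg and 140 mg/kg. This estimate means an expected step of a 1.2-fold lower number from compound 1 to compound 4 (0.08 log units; within the scatter), inside the usual scatter.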

Compound 4, dose for half-maximal effect: > 100 mg/kg
Compound 4: no number, only a limit; the forecaster's own chance of this, stated with the estimate: 20%; middle value at least 1.6-fold (0.22 log units) from the limit.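

In this assay compound 4 gives > 100 mg/kg, which is a limit of the assay and not a number. Among the compounds shown here, this is the first step that can be read at this place on the chain, with hydroxy in place of methyl: an at least 1.3-fold higher number from compound 1 to compound 4 (0.13 log units; that floor lies within the scatter). Only a floor is known for this step, so the true change may be small or large, but nothing here shows the hydroxy bringing the effect to smaller amounts, and the limit is now reached more often in the set: the limit of > 100 mg/kg in this assay, at which 2 of the 4 values shown sit.

From the compounds shown here alone, the real number for compound 4, and with it the true size of the step, stays open. Also open, going by these compounds, is how an amine or a methoxy group at the end of the chain, or a longer chain, would read in this assay.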